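This account rests on a few compounds, and the source may have more. Where it says the series, first, only, none or still open, it means among the compounds named here.

Measured so far:
compound 1 `O=C(c1ccc(-c2nnc(-c3ccccc3)o2)s1)C(F)(F)F`: 420 nM
compound 2 `O=C(c1ccc(-c2nc(-c3ccc(Cl)cc3Cl)no2)s1)C(F)(F)F`: 240 nM
compound 3 `O=C(c1ccc(-c2nc(CS(=O)(=O)c3cccs3)no2)s1)C(F)(F)F`: 35 nM

Of the compounds shown here, three sharing the trifluoromethyl ketone and thiophene core have been tested in an assay for inhibition of histone deacetylase 4 (Homo sapiens); on this read-out lower numbers stand for stronger inhibition and higher numbers for weaker inhibition. In this assay compound 1 gives 420 nM, compound 2 gives 240 nM and compound 3 gives 35 nM. Compound 2 thus holds the second highest of the three numbers; its value and that of compound 1 lie within the scatter of each other, while compound 3 shows a lower number by a margin beyond the scatter.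

Compound 4 `O=C(c1ccc(-c2nc(-c3ccc(F)cc3F)no2)s1)C(F)(F)F` is not yet measured. It differs from compound 2 in one place:
2,4-difluorophenyl in place of 2,4-dichlorophenyl on an aromatic carbon

Among the compounds with values here, no measured pair in this set isolates such a swap of halogens on the phenyl ring, so no step of this kind is on record. With nothing to point to a change beyond the scatter, compound 4 is expected to remain close to compound 2, the estimated step of a 1.5-fold higher number from compound 2 to compound 4 (0.16 log units; within the scatter) being small and pointing, if anywhere, toward a somewhat higher number. Compound 4 is therefore estimated at 350 nM, with a range from 120 nM to 1000 nM.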

Compound 4, half-maximal inhibitory concentration: 120 nM
Estimate against measurement, compound 4: 2.9-fold (0.46 log units) above; measured number inside the range.
By their numbers in this assay, from the lowest: compound 3; then compounds 4, 2 and 1 (each within the scatter of the next, the first and the last beyond it).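

In this assay, within the data shown here, putting 2,4-difluorophenyl in place of 2,4-dichlorophenyl on this aromatic carbon, between two ring nitrogen atoms, gives a 2.0-fold lower number from compound 2 to compound 4 (0.30 log units; within the scatter), the first step on record that isolates this position. It shows that this exchange of chlorine for fluorine at both ring sites, with the shared core unchanged, moves the read-out by no more than repeated measurements can differ, so compound 2 and compound 4 cannot be told apart here. Nothing available bears on how the two halogens compare at this position.

As far as these compounds go, it remains open whether a phenyl ring without any halogen, or one carrying a methoxy group or an amine, would stay as close to compound 2 on this core. Also open, from the compounds shown here alone, is whether a single chlorine or fluorine would be enough.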